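Dropping One Chloro Group from Compound 1

A few compounds are considered here, and "the series" means these few. Any claim that something is new, unique, unknown or untested is made for them only; others in the source may bear on it.

Compound 1, `CC1(C)Cc2c(OCc3ccccc3)ccc(C(=O)/C=C/c3ccc(Cl)cc3Cl)c2O1`, was tested in a functional assay on PC-3 cells (Homo sapiens) for antiproliferative activity, read by MTT assay, with a stated time of 48 h; on this read-out higher numbers stand for weaker inhibition and lower numbers for stronger inhibition. In this assay compound 1 gives only a limit, > 100000 nM, and not a number. Compound 2, `CC1(C)Cc2c(ccc(C(=O)/C=C/c3cn(-c4ccccc4)nc3-c3ccccc3)c2OCc2ccccc2)O1`, likewise gives only a limit in this assay, > 100000 nM. For the measured compounds named here, both values sit at the limit of > 100000 nM in this assay, at which 2 of the 2 values shown sit, so compound 1 stands at the limit beside the only other measured compound, and no step between two measured numbers exists here.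

Compound 3, `CC1(C)Cc2c(OCc3ccccc3)ccc(C(=O)/C=C/c3ccc(Cl)cc3)c2O1`, differs from compound 1 in one place: hydrogen in place of chloro on an aromatic carbon. Going by the values given here, no measured step shows how large such a change can be; the two measured compounds give only limits. The estimated step of a number no higher from compound 1 to compound 3 (the limit leaves the size open) is therefore set at none beyond the scatter, with this assay most likely again reporting only a limit rather than a number. Compound 3 is expected to give about 100000 nM in this assay, with a range from 30000 nM to 300000 nM, and the true value may well lie at or past the limit.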

Compound 3, half-maximal inhibitory concentration: > 100000 nM
Compound 3: a limit, no number (the forecaster's own chance of this, stated with the estimate: 80%); the middle value sits exactly at the limit.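

Compound 1 and compound 3 both give only a limit in this assay, not a number, so the step between them cannot be read: the limit of > 100000 nM in this assay, at which 3 of the 3 values shown sit.

The compounds shown leave open whether hydrogen in place of chloro changes the activity at all, and what true value any of these compounds has.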